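Compound 4: a non-aromatic ring replaces an aromatic one

The source may hold more compounds than are shown below. What is called first, only, known or untested is meant among the compounds shown, and "the series" means these compounds.

All three values below come from an ADME assay on the whole organism (strain Han-Wistar) for pharmacokinetics, with Rattus norvegicus as the target, read by LC-MS, at a dose of 2 mg/kg by the oral route (on this read-out higher numbers stand for higher exposure at the dose given and lower numbers for lower exposure), and share one core.

- compound 1 `CN1CCN(CCCS(=O)(=O)c2ccc3nc(NC(=O)NC(=O)c4cc(-n5cccn5)ccc4Cl)sc3c2)CC1` gives 1200 nM
- compound 2 `Cc1cc(C)n(-c2ccc(Cl)c(C(=O)NC(=O)Nc3nc4ccc(S(=O)(=O)CCCN5CCN(C)CC5)cc4s3)c2)n1` gives 78 nM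
- compound 3 `CN1CCN(CCCS(=O)(=O)c2ccc3nc(NC(=O)NC(=O)c4cc(-n5cccc5)ccc4Cl)sc3c2)CC1` gives 580 nM

Of these three numbers, the middle one belongs to compound 3. On either side of it lie a 2.1-fold lower number from compound 1 to compound 3 (0.32 log units; beyond the scatter) and a 7.4-fold higher number from compound 2 to compound 3 (0.87 log units; beyond the scatter) in the measured data.

Compound 4 `CN1CCN(CCCS(=O)(=O)c2ccc3nc(NC(=O)NC(=O)c4cc(N5CCCC5)ccc4Cl)sc3c2)CC1` differs from compound 3 in one group only. The whole change is pyrrolidin-1-yl in place of 1H-pyrrol-1-yl on an aromatic carbon and it sits on an aromatic carbon of a six-membered aromatic ring of carbon only, para to a chloro group.

Every measured swap at this place moved the number beyond the scatter, and the largest is a 15-fold lower number from compound 1 to compound 2 (1.19 log units; beyond the scatter) in this small set. For the measured compounds named here, none of the measured compounds carries a non-aromatic ring here, so the data hold no direct precedent. Compound 1 gives the highest number at 1200 nM and both changes made to it lowered the number, so a modest fall rather than a rise is expected in this assay with considerable uncertainty. The estimated step is a 1.9-fold lower number from compound 3 to compound 4 (0.29 log units; within the scatter) on this reasoning. Compound 4 is expected at 300 nM with an estimated range from 80 nM to 1000 nM for its measured value.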

Compound 4, maximal plasma concentration: 640 nM
Estimate against measurement, compound 4: 2.1-fold (0.33 log units) below; measured number inside the range.
By their numbers in this assay, from the lowest: compound 2; then compounds 3, 4 and 1 (each within the scatter of the next, the first and the last beyond it).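

Replacing the aromatic ring with its saturated counterpart changes little in this assay: the data show a 1.1-fold higher number from compound 3 to compound 4 (0.04 log units; within the scatter) even though the ring loses its aromatic character, so at this position aromaticity of the five-membered ring is not what sets the number for this pair. The non-aromatic ring also stays close to the best group seen so far, with a 1.9-fold lower number from compound 1 to compound 4 (0.27 log units; within the scatter) as the step, yet it stands clearly apart from the dimethylated ring, with an 8.2-fold higher number from compound 2 to compound 4 (0.91 log units; beyond the scatter) as the step, which leaves compound 2 as the only one of the four far from the rest, although compound 1 and compound 3 still differ from each other beyond the scatter. Nothing presented here offers a measured reason for any of these numbers.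

As far as these compounds go, it remains open whether two methyl groups on the pyrrolidine ring would lower the number as far as they do in compound 2 on the pyrazole ring. A six-membered ring such as piperidin-1-yl or morpholin-4-yl at this position, and an open-chain dimethylamino group, also remain untested among the compounds shown here.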